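Phenethyl to (1-phenylethyl)amino on the carbonyl carbon

This account rests on a few compounds, and the source may have more. Where it says the series, first, only, none or still open, it means among the compounds named here.

Among the measured compounds shown here, in a functional assay (plasma) with Oryctolagus cuniculus as the target (on this read-out lower numbers stand for stronger inhibition and higher numbers for weaker inhibition), compound 3 (`Cc1nc2cnccc2n1CC1CCN(C(=O)CCc2ccccc2)CC1`) gives 60 nM as the highest number of the three measured so far, and its steps to both others lie beyond the scatter. Compound 1 (`COC(=O)NC(CC(=O)N1CCC(Cn2c(C)nc3cnccc32)CC1)c1ccccc1`) gives 12 nM in the same read-out and compound 2 (`Cc1nc2cnccc2n1CC1CCN(C(=O)CC(C)(C)c2ccccc2)CC1`) gives 6.7 nM there.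

Compound 4 (`Cc1nc2cnccc2n1CC1CCN(C(=O)N[C@@H](C)c2ccccc2)CC1`) is still unmeasured. The difference (1-phenylethyl)amino in place of phenethyl on a carbonyl carbon amounts to (1-phenylethyl)amino in place of phenethyl on a carbonyl carbon.

For the measured compounds named here, two measured steps bear on it. The step of a 5.0-fold higher number from compound 1 to compound 3 (0.70 log units; beyond the scatter) comes with hydrogen in place of (methoxycarbonyl)amino, and the step of a 9.0-fold higher number from compound 2 to compound 3 (0.95 log units; beyond the scatter) comes with benzyl in place of 1-methyl-1-phenylethyl. Both are modest. Compound 4 has a branched chain like compound 1 and compound 2, whereas compound 3 at 60 nM has none, so a lower number is the likelier direction. Going by the values given here, no measured step covers a change on the carbonyl carbon itself, so the size remains loosely bounded and a step no larger than those two is assumed.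

In this assay the expected outcome is a 3.0-fold lower number from compound 3 to compound 4 (0.48 log units; beyond the scatter) as a modest move towards a lower number. Compound 4 is estimated at 20 nM with an expected range from 6 nM to 70 nM for this read-out.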

Compound 4, half-maximal inhibitory concentration: 41 nM
Beside the measured number, compound 4's estimate is 2.1-fold (0.31 log units) below it; low and high end bracket the measured number.
By their numbers in this assay, from the lowest: compounds 2 and 1 (each within the scatter of the next); then compounds 4 and 3 (each within the scatter of the next).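

Working notes on the carbonyl carbon: in this assay, placing (1-phenylethyl)amino there instead of phenethyl gives a 1.5-fold lower number from compound 3 to compound 4 (0.17 log units; within the scatter), so this read-out does not separate the two groups, even though the entering group brings a nitrogen, a hydrogen-bond donor and a defined stereocentre. The two earlier changes, both on saturated chain carbons, gave larger steps beyond the scatter, namely a 5.0-fold higher number from compound 1 to compound 3 (0.70 log units; beyond the scatter) and a 9.0-fold higher number from compound 2 to compound 3 (0.95 log units; beyond the scatter), whereas this first change on the carbonyl carbon itself stays within it. No supporting evidence is available to explain this outcome.

Open, on these data alone, is whether the opposite configuration at the stereocentre, plain benzylamino or (1-methyl-1-phenylethyl)amino on the same carbonyl carbon would give a step beyond the scatter from compound 4. Also open, as far as these compounds go, is whether the amide hydrogen of compound 4 contributes to the read-out, a question that an N-methyl-N-(1-phenylethyl)amino group on this carbon could address.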